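Ring-carbon configuration in a chemokine receptor antagonist pair

This account rests on a few compounds, and the source may have more. Where it says the series, first, only, none or still open, it means among the compounds named here.

Compound 1 `Cc1nn([C@H](C)c2ccc(Cl)cc2Cl)c2nc(N3CC[C@H](N4CCCC4)[C@H](C)C3)cnc12`: 69 nM
Compound 2 `Cc1nn([C@H](C)c2ccc(Cl)cc2Cl)c2nc(N3CC[C@@H](N4CCCCC4)[C@@H](C)C3)cnc12`: 803 nM

In a functional assay on cells for antagonist activity at C-C chemokine receptor type 4 (Homo sapiens), read by fluorescence and calcium flux, with stated times of 2.5 s and 45 s (on this read-out higher numbers stand for weaker inhibition and lower numbers for stronger inhibition), compound 2 gives 803 nM, the highest number of the two, and compound 1 gives 69 nM, a gap beyond the scatter. Compound 3 `Cc1nn([C@H](C)c2ccc(Cl)cc2Cl)c2nc(N3CC[C@H](N4CCCCC4)[C@H](C)C3)cnc12` is the unmeasured partner of compound 2: the two compounds have the same atoms and bonds and differ only in configuration as drawn: 2 of 3 stereo elements differ; a stereocentre at a saturated ring carbon is drawn R in compound 2 and S in compound 3; a stereocentre at a saturated ring carbon is drawn S in compound 2 and R in compound 3. Going by the values given here, no directly comparable step is measured. The configuration drawn for compound 3 matches that of compound 1, so a large drop in the read-out is expected, with an 8.0-fold lower number from compound 2 to compound 3 (0.90 log units; beyond the scatter) as the estimated step, because compound 1 gives 69 nM. Compound 3 is expected near 100 nM, within 30 nM to 400 nM.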

Compound 3, half-maximal inhibitory concentration: 42 nM
The estimate for compound 3 lay 2.4-fold (0.38 log units) above the measured number; measured number inside the range.
By their numbers in this assay, from the lowest: compounds 3 and 1 (each within the scatter of the next); then compound 2.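

In this assay, inverting the two saturated ring carbons gives a 19-fold lower number from compound 2 to compound 3 (1.28 log units; beyond the scatter), so the configuration as drawn decides the read-out in this pair: the fact that compounds 2 and 3 differ only in the configuration as drawn. With that configuration held, piperidin-1-yl in place of pyrrolidin-1-yl on a saturated ring carbon gives a 1.6-fold lower number from compound 1 to compound 3 (0.22 log units; within the scatter), and the two amines cannot be told apart here.

From the compounds shown here alone, both ring carbons change together, and the share of each in the step stays open. Also open, going by these compounds, is how morpholin-4-yl or dimethylamino would read on that ring carbon.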